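Adding a Carboxy Group to the Pyridyl of Compound 2

The source may report more compounds than this note shows. Statements on the series, on what has been measured and on what is new or still open speak of the compounds shown alone.

Compound 2 `CCC(C)(C)Cc1c[nH]c(CCc2ccc(-c3cccnc3)cc2)n1` was tested in a functional assay on HEK293 cells for agonist activity at Bombesin receptor subtype-3 (Homo sapiens), read by luminescence and calcium flux, with a stated time of 10 min (a higher number here means that more compound is needed for the effect, a lower number that less compound is needed), where compound 2 gives 98 nM. Among the two measured compounds this is the highest number, yet its nearest neighbour, compound 1 `CCC(C)(C)Cc1c[nH]c(CCc2ccc(-n3ccnn3)cc2)n1`, sits within the scatter: in this assay compound 1 gives 93 nM. For the measured compounds named here, the single measured step, a 1.1-fold higher number from compound 1 to compound 2 (0.02 log units; within the scatter), exchanges one ring for another on the same aromatic carbon and is too small to count as a change. Compound 3 `CCC(C)(C)Cc1c[nH]c(CCc2ccc(-c3cccnc3C(=O)O)cc2)n1` has not yet been measured. It differs from compound 2 by carboxy in place of hydrogen on an aromatic carbon. Going by the values given here, the one step available does not touch the pyridine itself and says nothing about a carboxy group entering on it, so no measured step bears on this change. The expectation for compound 3 therefore rests on the value of compound 2 alone and is stated with a wide range. Compound 3 is expected to give 180 nM in this assay, between 50 nM and 700 nM, a step of a 1.8-fold higher number from compound 2 to compound 3 (0.26 log units; within the scatter) that is expected to stay near the scatter in either direction.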

Compound 3, half-maximal effective concentration: 95 nM
Compound 3: middle estimate off by 1.9-fold (0.28 log units), on the high side; the range from low to high includes it.
By their numbers in this assay, from the lowest: compounds 1, 3 and 2 (each within the scatter of the next).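

In this assay, carboxy entering on the aromatic carbon next to the ring nitrogen, ortho to a large group, gives a 1.0-fold lower number from compound 2 to compound 3 (0.01 log units; within the scatter). This shows that 3 further heavy atoms, including 1 hydrogen-bond donor, can stand at this place on the pyridine without a change that can be read in this assay. The wider exchange gives a 1.0-fold higher number from compound 1 to compound 3 (0.01 log units; within the scatter), so 2-carboxypyridin-3-yl now stands with pyridin-3-yl and 1H-1,2,3-triazol-1-yl as three groups on the same aromatic carbon whose numbers lie within the scatter of one another, and no measurement at hand explains why the carboxy group leaves the number where it is.

The compounds shown leave open whether a methyl ester, a primary amide or an aminomethyl group at this same place would also stay within the scatter, and whether a carboxy group on another carbon of the pyridine would do so. They also leave open whether any group on this ring can move the number at all, since all three compounds keep the rest of the structure the same and none of the steps shown goes beyond the scatter.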